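Anilide substituent change at the amide nitrogen of compound 1

The source may hold more compounds than are shown below. What is called first, only, known or untested is meant among the compounds shown, and "the series" means these compounds.

Compound 1 `COc1ccc2c(=O)c(/C=C/C(=O)Nc3cccc(Cl)c3)coc2c1` is the weakest-characterised member of this set: in a functional assay (QGY7701 cells, Homo sapiens) for inhibition, read by MTT assay, with a stated time of 48 h (a higher number here means a weaker inhibitor, a lower number a stronger inhibitor), compound 1 gives > 100000 nM, which is a limit of the assay and not a number. Going by the values given here, that compound 1 sits at a limit is the one piece of evidence on its standing (the limit of > 100000 nM in this assay, at which 1 of the 3 values shown sits). Compound 2 `COc1cccc(NC(=O)/C=C/c2coc3cc(OC)ccc3c2=O)c1` gives 39100 nM in this assay, and compound 3 `COc1ccc2c(=O)c(/C=C/C(=O)NCc3ccc(C)cc3)coc2c1` gives 10200 nM.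

The step to compound 4 `COc1ccc2c(=O)c(/C=C/C(=O)Nc3ccc(C)cc3)coc2c1` changes the group on the amide-type nitrogen: 4-methylphenyl in place of 3-chlorophenyl on an amide-type nitrogen. Among the compounds with values here, three measured steps bear on it. Replacing the same group with another aryl gave an at least 2.5-fold lower number from compound 1 to compound 2 (0.40 log units; beyond the scatter); moving to a benzyl gave an at least 9.8-fold lower number from compound 1 to compound 3 (0.99 log units; beyond the scatter); and between the two arylated members the difference was a 3.8-fold lower number from compound 2 to compound 3 (0.58 log units; beyond the scatter). Every change away from the 3-chlorophenyl of compound 1 has therefore lowered the number in this assay beyond the scatter, though only compound 2 and compound 3 support this and both steps start from a limit.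

A lower number than compound 1 is expected for compound 4, with a step of about an at least 2.8-fold lower number from compound 1 to compound 4 (0.45 log units; beyond the scatter) estimated. Compound 4 is estimated at 35000 nM, within a range of 8000 nM to 120000 nM.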

Compound 4, half-maximal inhibitory concentration: 39300 nM
Compound 4: middle estimate off by 1.1-fold (0.05 log units), on the low side, and the stated range covers the measured number.
By their numbers in this assay, from the lowest: compound 3; then compounds 2 and 4 (each within the scatter of the next). At a limit, above all of these: compound 1.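

In this assay two anilides now carry different aryl groups, 3-methoxyphenyl and 4-methylphenyl, and a 1.0-fold higher number from compound 2 to compound 4 (0.00 log units; within the scatter) leaves them indistinguishable, so the exchange of these two aryl groups has no readable effect in this pair. With the methyl-bearing aromatic ring kept, the change from 4-methylbenzyl to 4-methylphenyl gives a 3.9-fold higher number from compound 3 to compound 4 (0.59 log units; beyond the scatter) and shows that compound 3 stands apart from both anilides with measured numbers, which one anilide alone could not establish. The second replacement of 3-chlorophenyl, an at least 2.5-fold lower number from compound 1 to compound 4 (0.40 log units; beyond the scatter) in this series, again clears the value of compound 1, but its size is only a bound since compound 1 sits at a limit: the limit of > 100000 nM in this assay, at which 1 of the 4 values shown sits.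

Still open, from the compounds shown here alone, is whether the 3-chlorophenyl group as a whole sets compound 1 apart or only its chlorine, a question that 4-chlorophenyl and 3-methylphenyl on the same nitrogen would separate. Also open, going by these compounds, is whether the trend from anilide to benzyl continues with a longer chain such as 2-phenylethyl, or holds for an unsubstituted benzyl.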